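The compounds below may be only part of what the source reports. "The series", "measured", "known", "first", "only" and "open" are said of these compounds alone.

Compound 1, with the structure `CC(C)CN1CCCC[C@H]1C(=O)Nc1cc(C(C)(C)C)on1`, gives 0.1 h in an ADME assay (liver) for metabolic stability, with Liver microsome (Homo sapiens) as the target, read by LC-MS, using microsomes and NADPH, tested at 1 uM; on this read-out lower numbers stand for a shorter-lived compound and higher numbers for a longer-lived compound.
Compound 2, with the structure `CC(C)(C)c1cc(NC(=O)[C@@H]2CCCCN2C(=O)N2CCCCC2)no1`, gives 0.233 h in this assay.
Compound 3, with the structure `CC(=O)N1CCN(C(=O)N2CCCC[C@H]2C(=O)Nc2cc(C(C)(C)C)on2)CC1`, gives > 2 h in this assay.

The three measured compounds share one core and differ only in the group on the ring amine nitrogen. Across them the half-life climbed in two steps: first a 2.3-fold higher number from compound 1 to compound 2 (0.37 log units; beyond the scatter), then an at least 8.5-fold higher number from compound 2 to compound 3 (0.93 log units; beyond the scatter). Compound 3 therefore stands at the top of the numbers seen so far. Its value, however, is not a number but a limit of this assay, as shown by the limit of > 2 h in this assay, at which 1 of the 3 values shown sits, so how far beyond it compound 3 truly lies is unknown.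

Compound 4, with the structure `CC(C)(C)c1cc(NC(=O)[C@@H]2CCCCN2C(=O)N2CCSCC2)no1`, differs from compound 3 in one place: thiomorpholin-4-yl in place of 4-acetylpiperazin-1-yl on a carbonyl carbon. The measured step that bears on this change is an at least 8.5-fold higher number from compound 2 to compound 3 (0.93 log units; beyond the scatter), since it also swapped the ring attached to that carbonyl carbon. Because of an at least 8.5-fold higher number from compound 2 to compound 3 (0.93 log units; beyond the scatter), going back to a ring without the acetyl group is expected to move the half-life downward, and the step of an at least 5.0-fold lower number from compound 3 to compound 4 (0.69 log units; beyond the scatter) is the expected result. Compound 4 is therefore estimated to give 0.4 h in this assay, within a range from 0.15 h to 1.5 h.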

Compound 4, half-life: < 0.0834 h
Compound 4 gave a limit, no number; the forecaster's own chance of this, stated with the estimate: 15%; middle value at least 4.7-fold (0.68 log units) away from the limit.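

Replacing 4-acetylpiperazin-1-yl with thiomorpholin-4-yl on a carbonyl carbon gives an at least 23-fold lower number from compound 3 to compound 4 (1.37 log units; beyond the scatter), so in this assay two rings of the same size, each with 2 hetero atoms, can sit at opposite ends of the half-life values shown. A second hetero atom in the ring is therefore not enough for a longer half-life, as thiomorpholin-4-yl also falls short of piperidin-1-yl, with an at least 2.7-fold lower number from compound 2 to compound 4 (0.44 log units; beyond the scatter); against isobutyl the reading is an at least 1.1-fold lower number from compound 1 to compound 4 (0.07 log units; that floor lies within the scatter), so no order can be claimed for that pair. The result for compound 4 is a limit of the assay and not a number: the limit of < 0.0834 h in this assay, at which 1 of the 4 values shown sits.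

Going by these compounds, compound 3 also carries a limit and not a number, so the full size of the change stays open: the limit of > 2 h in this assay, at which 1 of the 4 values shown sits. Also open is whether the acetyl group or the ring nitrogen that bears it goes with the long half-life of compound 3, a question that a morpholin-4-yl ring or a piperazine ring with a free amine in the same place would help to answer.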